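Series notes: from compound 2 to compound 3

A few compounds are considered here, and "the series" means these few. Any claim that something is new, unique, unknown or untested is made for them only; others in the source may bear on it.

In an ADME assay on HEL cells (Homo sapiens) for cytotoxicity (on this read-out higher numbers stand for lower toxicity in this test and lower numbers for higher toxicity in this test), compound 2 `O=C(COc1cccc2ccccc12)N/N=C/c1ccc(Br)cc1` gives 100 ug/mL, the highest of the two numbers at hand. Compound 1 `COc1ccc(/C=N/NC(=O)COc2cccc3ccccc23)cc1O` gives 27.7 ug/mL in this assay, a lower number by a gap beyond the scatter. Compound 3 `Cc1ccc(/C=N/NC(=O)COc2cccc3ccccc23)cc1` differs from compound 2 by methyl in place of bromo on an aromatic carbon. Among the compounds with values here, no measured pair covers this change, so the expectation rests on compound 2 alone. A small step toward a lower number in this assay, or none beyond the scatter, is expected, namely a 1.4-fold lower number from compound 2 to compound 3 (0.15 log units; within the scatter). Compound 3 is estimated at 70 ug/mL, within 30 ug/mL to 110 ug/mL.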

Compound 3, half-maximal cytotoxic concentration: 80.1 ug/mL
Estimate against measurement, compound 3: 1.1-fold (0.06 log units) below; the measured number falls inside the stated range.
By their numbers in this assay, from the lowest: compound 1; then compounds 3 and 2 (each within the scatter of the next).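

In this assay the change from 4-bromophenyl to 4-methylphenyl gives a 1.2-fold lower number from compound 2 to compound 3 (0.10 log units; within the scatter) and so stays within the scatter. Within the data shown here, this is the first single-place step, and it shows that, on the aromatic carbon para to a large group, bromo and methyl cannot be told apart in this read-out. No measurement at hand bears on a cause for this result.

As far as these compounds go, whether an amine or a carboxylic acid at this position would also leave the read-out unchanged remains open. Also open, from the compounds shown here alone, is whether the methoxy or the hydroxy group of compound 1 accounts for its gap to compound 2.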